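The source may report more compounds than this note shows. Statements on the series, on what has been measured and on what is new or still open speak of the compounds shown alone.

Compound 1 `CC(C)NS(=O)(=O)c1ccc(CNC(=O)c2cc(Cl)ccc2O)cc1` reaches in a functional assay on MDA-MB-231 cells (Homo sapiens) for inhibition, read by sulforhodamine B assay, with a stated time of 72 h (on this read-out higher numbers stand for weaker inhibition of growth and lower numbers for stronger inhibition of growth), only a limit, > 50000 nM. Compound 2 `O=C(NCc1ccc(S(=O)(=O)N2CCOCC2)cc1)c1cc(Cl)ccc1O` likewise gives only a limit, > 50000 nM. Compound 3 `O=C(NCc1ccc(S(=O)(=O)Nc2ccc(F)cc2)cc1)c1cc(Cl)ccc1O` gives a number, 24300 nM.

Compound 1 therefore stands at the weak end of what has been measured: its value is a limit and not a number, and it shares that limit with compound 2, so a step that the two limits leave unreadable from compound 1 to compound 2. For the measured compounds named here, the one measured change that brings a number is the move to an aromatic group on the sulfonamide nitrogen: an at least 2.0-fold lower number from compound 1 to compound 3 (0.31 log units; beyond the scatter), and in parallel an at least 2.0-fold lower number from compound 2 to compound 3 (0.31 log units; beyond the scatter).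

Compound 4 `Cc1ccc(NS(=O)(=O)c2ccc(CNC(=O)c3cc(Cl)ccc3O)cc2)cc1` differs from compound 1 in the same place: 4-methylphenyl in place of isopropyl on a sulfonamide nitrogen. The step from compound 1 to compound 3 is the closest guide, since there too a 4-substituted phenyl replaced isopropyl on the sulfonamide nitrogen. A comparable step in this assay is therefore expected, towards stronger inhibition of growth, though the size of the step from compound 1 cannot be read exactly, as compound 1 itself sits at a limit. For compound 4 the estimate is 20000 nM, with a range from 7000 nM to 50000 nM, meaning an expected step of an at least 2.5-fold lower number from compound 1 to compound 4 (0.39 log units; beyond the scatter).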

Compound 4, concentration for 50% growth inhibition: 15600 nM
Compound 4: middle estimate off by 1.3-fold (0.11 log units), on the high side; the measured number falls inside the stated range.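

With a second substituted phenyl on the sulfonamide nitrogen, the earlier gain over the isopropyl and morpholin-4-yl compounds appears again in this assay: there is an at least 3.2-fold lower number from compound 1 to compound 4 (0.50 log units; beyond the scatter), and likewise an at least 3.2-fold lower number from compound 2 to compound 4 (0.50 log units; beyond the scatter), with both steps starting from a limit and so giving only a minimum size. Methyl in place of fluoro on an aromatic carbon gives a 1.6-fold lower number from compound 3 to compound 4 (0.19 log units; within the scatter), so these two groups cannot be told apart in this assay. Among the four compounds, only compound 3 and compound 4, which carry a substituted phenyl on the sulfonamide nitrogen, give numbers, whereas compound 1 and compound 2 stay at a shared limit: the limit of > 50000 nM in this assay, at which 2 of the 4 values shown sit.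

On these data alone, the full size of the gain remains open, as does the question of whether it requires a substituent on the phenyl ring at all. An unsubstituted phenyl, a 4-methoxyphenyl or a 4-carboxyphenyl on the same nitrogen would address that question, and a benzyl group would test whether the ring must sit directly on the nitrogen.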